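Quinolinone imines: replacing anilino with butyl

This account rests on a few compounds, and the source may have more. Where it says the series, first, only, none or still open, it means among the compounds named here.

Measured so far:
- compound 1 `Cc1ccc2[nH]c(=O)c(/C=N/Nc3ccc([N+](=O)[O-])cc3[N+](=O)[O-])cc2c1` — "not active" (no number reported)
- compound 2 `Cc1ccc2[nH]c(=O)c(/C=N/Nc3ccccc3)cc2c1` — 309000 nM
- compound 3 `N/N=C/c1cc2ccccc2[nH]c1=O` — 184000 nM

In a functional assay, read by spectrophotometry, with a stated time of 5 min (on this read-out higher numbers stand for weaker inhibition and lower numbers for stronger inhibition), compound 2 gives 309000 nM. In this assay compound 3 gives 184000 nM, and the gap between compound 2 and compound 3 lies within the usual scatter, so the two cannot be told apart. Compound 1, in this assay, gives "not active" (no number reported) and no number, so compound 2 sits with compound 3 as one of the two numbers that the series has, with nothing yet that sets it apart.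

Compound 4 `CCCC/N=C/c1cc2cc(C)ccc2[nH]c1=O` has not been measured in this assay. It differs from compound 2 in one place: butyl in place of anilino on a double-bonded nitrogen. Among the measured compounds shown here, no step between measured compounds covers a change of this kind, so there is nothing to calibrate it against; the only comparison at hand, compound 2 against compound 3, shows that two different groups on that nitrogen sit within the scatter of each other.

On that basis the step from compound 2 to compound 4 is expected to be small, a 1.1-fold higher number from compound 2 to compound 4 (0.05 log units; within the scatter), with no clear direction beyond the scatter. Compound 4 is therefore estimated at 350000 nM, within a range of 120000 nM to 1000000 nM.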

Compound 4, half-maximal inhibitory concentration: 379000 nM
Compound 4: middle estimate off by 1.1-fold (0.03 log units), on the low side, within the range that was stated.
By their numbers in this assay, from the lowest: compounds 3, 2 and 4 (each within the scatter of the next, the first and the last beyond it).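

In this assay, among the compounds shown here, the change at this place, butyl in place of anilino on a double-bonded nitrogen, gives a 1.2-fold higher number from compound 2 to compound 4 (0.09 log units; within the scatter) and is the only step that can be read at this position. The change takes away the six-membered aromatic ring of carbon only and the hydrogen-bond donor and acceptor counted on anilino, and the group goes from 7 heavy atoms to 4, yet the two compounds cannot be told apart; in this one pair, neither that ring nor that donor and acceptor shows up as needed at this place for the activity seen in this assay. Nothing measured here speaks to the reason for this result.

Still open, from the compounds shown here alone, is whether any group on this nitrogen can move the number beyond the scatter, for instance a longer chain such as octyl, or a butyl chain ending in an amine or a carboxylic acid. Also open, going by these compounds, is whether butyl and anilino stay this close on a core with other substituents, as a single pair on a single core does not show that.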